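Chloro for methoxy on an amide nitrogen: an expectation

The source may hold more compounds than are shown below. What is called first, only, known or untested is meant among the compounds shown, and "the series" means these compounds.

In a functional assay on U-251 cells (Homo sapiens) for inhibition, read by MTT assay, with a stated time of 2 days (a higher number here means a weaker inhibitor of growth, a lower number a stronger inhibitor of growth), three compounds have been measured:

compound 1, `Nc1ccccc1NC(=O)c1ccc(NCC(=O)Nc2cccc([N+](=O)[O-])c2)cc1`: 52000 nM
compound 2, `COc1ccc(NC(=O)CNCCCC(=O)Nc2ccccc2N)cc1`: > 100000 nM
compound 3, `Nc1ccccc1NC(=O)c1ccc(NCC(=O)Nc2ccc([N+](=O)[O-])cc2)cc1`: 42500 nM

Compound 2 gives only a limit in this assay, not a number, and so stands at the weak end of what this assay reports (the limit of > 100000 nM in this assay, at which 1 of the 3 values shown sits). Compound 4, `Nc1ccccc1NC(=O)CCCNCC(=O)Nc1ccccc1Cl`, differs from compound 2 in one place: 2-chlorophenyl in place of 4-methoxyphenyl on an amide-type nitrogen.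

Among the compounds with values here, the only measured step between two compounds that differ in one place is a 1.2-fold lower number from compound 1 to compound 3 (0.09 log units; within the scatter). That step also exchanges one aryl group on an amide-type nitrogen, and it lay within the scatter, though it sits on the core of compound 1 rather than that of compound 2, so it is only a loose guide here. Compound 4 is accordingly expected to show no step beyond the scatter, a number no higher from compound 2 to compound 4 (the limit leaves the size open). Compound 4 is estimated at 100000 nM, in a range from 40000 nM to 250000 nM, and is expected most likely to give again only a limit.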

Compound 4, concentration for total growth inhibition: > 100000 nM
Compound 4: a limit, no number; the forecaster's own chance of this, stated with the estimate: 70%; the middle value lies on the limit itself.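

Within the data shown here, compound 4, like compound 2, gives only a limit and not a number, so no step between compound 2 and compound 4 can be read. The compounds shown leave open whether 2-chlorophenyl in place of 4-methoxyphenyl on an amide-type nitrogen changes growth inhibition at all.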